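Aryl Sulfonate Exchange on a Shared Core

The source may report more compounds than this note shows. Statements on the series, on what has been measured and on what is new or still open speak of the compounds shown alone.

Compound 1 `O=C(O)CCCCCCC(=O)Nc1ccc(C2=C(c3ccc(O)cc3)C3CC(S(=O)(=O)Oc4ccccc4C(F)(F)F)C2O3)cc1` gives 26100 nM in a functional assay on MCF7 cells (Homo sapiens) for inhibition, read by MTT assay, with a stated time of 72 h; on this read-out higher numbers stand for weaker inhibition and lower numbers for stronger inhibition.
Compound 2 `COc1ccccc1OS(=O)(=O)C1CC2OC1C(c1ccc(NC(=O)CCCCCCC(=O)NO)cc1)=C2c1ccc(O)cc1` gives 25800 nM in this assay.
Compound 3 `O=C(CCCCCCC(=O)Nc1ccc(C2=C(c3ccc(O)cc3)C3CC(S(=O)(=O)Oc4ccc(Br)cc4)C2O3)cc1)NO` gives 17100 nM in this assay.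

The three numbers lie within the scatter of one another, so compound 1 cannot be told apart from compound 2 or compound 3 in this assay. Compound 4 `Cc1ccc(OS(=O)(=O)C2CC3OC2C(c2ccc(NC(=O)CCCCCCC(=O)O)cc2)=C3c2ccc(O)cc2)cc1` differs from compound 1 in one place: 4-methylphenyl in place of 2-(trifluoromethyl)phenyl on an oxygen. Among the compounds with values here, one measured step bears on this, an exchange of the aryl group on the same oxygen, and it read a 1.5-fold lower number from compound 2 to compound 3 (0.18 log units; within the scatter). That step stayed within the scatter. Compound 4 is therefore expected to show no step beyond the scatter, a 1.1-fold lower number from compound 1 to compound 4 (0.04 log units; within the scatter). Compound 4 is estimated at 24000 nM, in a range from 10000 nM to 55000 nM.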

Compound 4, half-maximal inhibitory concentration: 60500 nM
The estimate for compound 4 lay 2.5-fold (0.40 log units) below the measured number, and the stated range ends below it.
By their numbers in this assay, from the lowest: compounds 3, 2 and 1 (each within the scatter of the next); then compound 4.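

In this assay the exchange of aryl groups on the oxygen bound to the sulfonyl sulfur gave a 2.3-fold higher number from compound 1 to compound 4 (0.37 log units; beyond the scatter) and so showed that a change at this position can move the number beyond the scatter, which the earlier exchange had not shown. Nothing given here accounts for this step. The compounds shown leave open whether the loss of trifluoromethyl, the gain of methyl or the new place of the group on the ring matters. They also leave open how an amine or a nitrile on this aryl group would read.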